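Fluoro in place of hydrogen on the core of compound 1

The source may report more compounds than this note shows. Statements on the series, on what has been measured and on what is new or still open speak of the compounds shown alone.

Compound 1 `COc1ccc(S(=O)(=O)/C=C/c2ccccn2)cc1` is the parent of the series. Going by the values given here, in an ADME assay on BV-2 cells (Mus musculus) for cytotoxicity, with a stated time of 24 h, tested at 50 uM (on this read-out lower numbers stand for a stronger effect and higher numbers for a weaker effect at the one concentration tested), compound 1 gives 100%, the highest of the three numbers so far. Compound 2 `COc1ccc(S(=O)(=O)/C=C/c2cccc(Cl)n2)cc1` gives 85% in this assay, and compound 3 `COc1ccc(S(=O)(=O)/C=C/c2ccc(Cl)cn2)cc1` gives 84.1%. Both measured steps put chloro in place of hydrogen on an aromatic carbon: a number 15 percentage points lower from compound 1 to compound 2 (beyond the scatter), and a number 15.9 percentage points lower from compound 1 to compound 3 (beyond the scatter). Each of these is a modest lowering beyond the scatter, and the two agree closely with each other despite sitting at different places on the core.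

Compound 4 `COc1ccc(S(=O)(=O)/C=C/c2ncccc2F)cc1` is not yet measured. It differs from compound 1 by fluoro in place of hydrogen on an aromatic carbon, on an aromatic carbon of a six-membered aromatic ring with one nitrogen, ortho to a large group and two atoms from the ring nitrogen. Among the compounds with values here, no measured step exchanges hydrogen for fluoro, so the chloro steps are the only guide, and both are modest. A step of similar size or smaller, downward, is therefore expected; the step is estimated as a number 9 percentage points lower from compound 1 to compound 4 (within the scatter). For compound 4 the expected value in this assay is 91%, with a range from 78% to 102%.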

Compound 4, a percentage reported as activity, at one concentration (the size of the read-out at that concentration, not a potency): 86.6%
For compound 4 the middle estimate is 4.4 percentage points above the measured one, within the range that was stated.
By their numbers in this assay, from the lowest: compounds 3, 2 and 4 (each within the scatter of the next); then compound 1.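

In this assay, a number 13.4 percentage points lower from compound 1 to compound 4 (beyond the scatter) shows that the lowering seen with chloro is also reached with fluoro, a single-atom replacement, and at a further place on the core of compound 1: ortho to a large group and two atoms from the ring nitrogen. The downward change is therefore tied neither to chloro alone nor to the two places occupied by chloro in compound 2 and compound 3, since all three replacements of hydrogen by halogen shown here lower the number from that of compound 1, and none of the compounds shown goes against this. No measurement on hand accounts for the step at this position, so the result stands as an observation without an explanation.

Still open, as far as these compounds go, is whether chloro at this same place gives a step like the one with fluoro, and whether fluoro at the places held by chloro in compound 2 and compound 3 does the same. Also open is whether a larger or different group here, such as an amine, a carboxylic acid or a longer chain, leaves the step modest or moves the number further in this assay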